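Fluorine on the Core of Compound 2: An Expected Step

This account rests on a few compounds, and the source may have more. Where it says the series, first, only, none or still open, it means among the compounds named here.

In a functional assay on DU-145 cells (Homo sapiens) for cytotoxicity, read by MTT assay, with a stated time of 2 days, tested at 10 uM (a lower number here means less inhibition, a higher number more inhibition at the concentration tested (going by the name of the read-out)), compound 1 `CN(C)CCCNc1nc(NCc2ccco2)c2ccccc2n1` has "not determined" (no result reported), so no result is reported for it. Among the compounds with values here, compound 2 `Cc1cccc(N2CCN(CCCCNc3nc(NCc4ccco4)c4ccccc4n3)CC2)c1C` is the only compound with a number: in this assay compound 2 gives 93.6%, which leaves little room for a higher read-out. Compound 3 `Cc1cccc(N2CCN(CCCCNc3nc(NCc4ccco4)c4cc(F)ccc4n3)CC2)c1C` differs from compound 2 by fluoro in place of hydrogen on an aromatic carbon. Within the data shown here, no pair of measured compounds shows this change, so its effect here is unknown. The step is expected to stay within the scatter, or to fall only slightly, at a number 3.6 percentage points lower from compound 2 to compound 3 (within the scatter). Compound 3 is therefore estimated at 90%, within 75% to 99%.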

Compound 3, a percentage reported as inhibition, at one concentration (the size of the read-out at that concentration, not a potency): 93.4%
Beside the measured number, compound 3's estimate is 3.4 percentage points below it; the measured number falls inside the stated range.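

In this assay, fluoro in place of hydrogen on an aromatic carbon gives a number 0.2 percentage points lower from compound 2 to compound 3 (within the scatter), the first step measured at this position. The position therefore accepts fluoro with no change beyond the scatter, though only at one concentration, and with both compounds near the top of the read-out. Nothing given here accounts for this result.

As far as these compounds go, whether chloro, methoxy or an amine on the same carbon would keep the read-out this high remains open. So does the outcome of fluoro on the other aromatic carbons of the shared core.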